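The source may report more compounds than this note shows. Statements on the series, on what has been measured and on what is new or still open speak of the compounds shown alone.

Working notes on the series. In a functional assay on COLO 205 cells (Homo sapiens) for cytotoxicity, read by MTT assay, with a stated time of 48 h (a lower number here means a stronger inhibitor, a higher number a weaker inhibitor), compound 1 `Fc1cccc(-c2nc(Nc3ccccc3)c3cc(F)ccc3n2)c1` gives 49700 nM. For compound 2 `COc1ccccc1Nc1nc(-c2cccc(F)c2)nc2ccc(F)cc12` this assay returns only a limit, > 50000 nM. Compound 3 `Fc1cccc(-c2nc(Nc3ccccc3F)c3cc(F)ccc3n2)c1` likewise stands at a limit, > 50000 nM. It is one of the two compounds covered by the limit of > 50000 nM in this assay, at which 2 of the 3 values shown sit. The steps onto compound 3, a number no lower from compound 1 to compound 3 (the limit leaves the size open) and a step that the two limits leave unreadable from compound 2 to compound 3, are therefore without readable size, as is a number no lower from compound 1 to compound 2 (the limit leaves the size open). Compound 4 `Fc1cccc(-c2nc(Nc3ccccc3Cl)c3cc(F)ccc3n2)c1` differs from compound 3 by chloro in place of fluoro on an aromatic carbon. Within the data shown here, no measured step carries this change, and the steps that touch the same position give no size, so nothing points to a gain. Compound 4 is therefore expected to stay near the limit, the step from compound 3 being estimated as a number no higher from compound 3 to compound 4 (the limit leaves the size open). The estimate for compound 4 is 50000 nM, between 15000 nM and 150000 nM.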

Compound 4, half-maximal inhibitory concentration: > 50000 nM
Compound 4: only a limit was reported; the forecaster's own chance of this, stated with the estimate: 55%; the middle value sits exactly at the limit.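

Chloro on this aromatic carbon, ortho to a large group, gives no more of a readable value than fluoro or methoxy, so three different groups at this position now end at the same limit: the limit of > 50000 nM in this assay, at which 3 of the 4 values shown sit.
Only compound 1, with hydrogen at this position, keeps a number, 49700 nM. Going from hydrogen to chloro here reads as a number no lower from compound 1 to compound 4 (the limit leaves the size open). The other new steps onto compound 4 cannot be read in size.

From the compounds shown here alone, what an amine or a carboxylic acid would give at this position stays open. So does whether any group here can bring a value under the limit.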